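The source may report more compounds than this note shows. Statements on the series, on what has been measured and on what is new or still open speak of the compounds shown alone.

Compound 1 `Cc1cn(Cc2cc(Br)ccc2OCc2ccccc2)nc1C(=O)O`: 1350 nM
Compound 2 `O=C(O)c1nn(Cc2cc(Br)ccc2OCc2ccccc2)cc1CO`: < 2000 nM, which is a limit of the assay and not a number.
Compound 3 `Cc1cc(C(=O)O)nn1Cc1cc(Br)ccc1OCc1ccc(Cl)cc1Cl`: 0.49 nM

In a functional assay on CHO-K1 cells for antagonist activity at prostaglandin E2 receptor EP1 subtype (Homo sapiens), read by FLIPR (on this read-out higher numbers stand for weaker inhibition and lower numbers for stronger inhibition), compound 3 holds the lower of the two numbers; the nearer of the others, compound 1, gives a far higher number, beyond the scatter. Compound 4 `Cc1cc(C(=O)O)nn1Cc1cc(Br)ccc1OCc1ccc(Cl)cc1` differs from compound 3 by hydrogen in place of chloro on an aromatic carbon, 2,4-dichlorobenzyl becoming 4-chlorobenzyl. Going by the values given here, the only measured step, a step that the limit leaves unreadable from compound 1 to compound 2, touches another position, and its size is unreadable because the limit of < 2000 nM in this assay, at which 1 of the 3 values shown sits, caps compound 2. Among the compounds with values here, no measured step therefore speaks to the loss of this chloro. Compound 4 is expected to be somewhat weaker, by an estimated 4.1-fold higher number from compound 3 to compound 4 (0.61 log units; beyond the scatter). Compound 4 is estimated at 2 nM, ranging from 0.5 nM to 10 nM.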

Compound 4, inhibition constant: 8.71 nM
Compound 4: the middle estimate sits 4.4-fold (0.64 log units) below what was measured; the range from low to high includes it.
By their numbers in this assay, from the lowest: compound 3; then compound 4; then compound 1.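

In this assay, going by these compounds alone, removing one chloro from the 2,4-dichlorobenzyl group gives an 18-fold higher number from compound 3 to compound 4 (1.25 log units; beyond the scatter), the first readable step at this place, on an aromatic carbon ortho to a large group. The change is large, so this chloro counts for much of the strength of compound 3, although compound 4, with its 4-chlorobenzyl group, still gives 8.71 nM. Nothing measured here accounts for the size of this step. The compounds shown leave open how a fluoro, a methyl or a methoxy group would fare at this place. They also leave open what the remaining chloro contributes.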